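The source may hold more compounds than are shown below. What is called first, only, known or untested is meant among the compounds shown, and "the series" means these compounds.

Working notes on the series. Three compounds have numbers in an assay on HEK293 cells for antagonist activity at transient receptor potential cation channel subfamily V member 3 (Homo sapiens), read by FLIPR and calcium flux; a lower number here means a stronger inhibitor, a higher number a weaker inhibitor. Compound 1 `OC(c1cc(F)ccn1)C1(c2ccc(Cl)c(Cl)c2)CCC1` gives 640 nM in this assay. Compound 3 `O[C@H](c1ncccn1)C1(c2ccc(Cl)c(Cl)c2)CCC1` gives 370 nM in this assay. Compound 2 `CN1CC(c2ccc(C(F)(F)F)cc2)(C(O)c2ccccn2)C1` gives 6630 nM in this assay, which is the highest of the three numbers; its nearest neighbour is compound 1, a gap beyond the scatter, and the gap to compound 3 is wider still. Going by the values given here, compound 2 also stands apart in structure from compounds 1 and 3, which share the cyclobutane-and-dichlorophenyl arrangement, so no single-change step among the measured compounds bears on it.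

The next compound, compound 4 `OC(c1ccccn1)C1(c2ccc(C(F)(F)F)cc2)CNC1`, differs from compound 2 in one place: hydrogen in place of methyl on an amine nitrogen in a ring. Among the compounds with values here, no measured pair shows this change in isolation, so the size and direction of the step from compound 2 to compound 4 cannot be read from the data. The working expectation is a change of modest size, possibly within the scatter, with no direction favoured by anything shown.

Compound 4 is therefore expected to land near compound 2 in this assay, with the step from compound 2 to compound 4 estimated as a 1.5-fold lower number from compound 2 to compound 4 (0.17 log units; within the scatter). The estimate for compound 4 in this assay is 4500 nM, in a range from 1500 nM to 13000 nM.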

Compound 4, antagonist equilibrium constant: 6680 nM
Compound 4: the middle estimate sits 1.5-fold (0.17 log units) below what was measured, and the stated range covers the measured number.
By their numbers in this assay, from the lowest: compounds 3 and 1 (each within the scatter of the next); then compounds 2 and 4 (each within the scatter of the next).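

On the amine nitrogen in the four-membered non-aromatic ring, hydrogen in place of methyl gives a 1.0-fold higher number from compound 2 to compound 4 (0.00 log units; within the scatter) in this assay. Going by these compounds alone, this is the first single-change step, and it shows that, in this pair, removing the methyl from the ring nitrogen leaves the number within the scatter, so the pair gives no sign that the methyl matters to the read-out. The result rests on one pair and sets no pattern beyond compound 2 and compound 4, and no measured property is available that could account for the size of this step.

Open is whether the ring nitrogen stays as insensitive with larger or differently built groups on it, such as an ethyl, a benzyl or an acetyl group, since hydrogen and methyl are the only two substituents shown at this position. Also open, going by these compounds, is whether a change elsewhere on compound 4, such as a chlorine or a nitrile in place of the trifluoromethyl group, would move the number in this assay beyond the scatter.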